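A few compounds are considered here, and "the series" means these few. Any claim that something is new, unique, unknown or untested is made for them only; others in the source may bear on it.

Compound 1 `C=CC(=O)Nc1cccc(NC(=O)CSc2nc(Nc3ccccc3)c3ccccc3n2)c1` and compound 2 `C=CC(=O)Nc1cccc(NC(=O)CSc2nc(Nc3cccc(OC)c3)c3ccccc3n2)c1` share one core and differ only on the phenyl attached to the ring nitrogen. In a functional assay on PC-3 cells (Homo sapiens) for inhibition, read by MTT assay, with a stated time of 72 h (on this read-out lower numbers stand for stronger inhibition and higher numbers for weaker inhibition), compound 1 gives 8740 nM, and in the same test compound 2 gives 34900 nM. For the measured compounds named here, the single measured step, a 4.0-fold higher number from compound 1 to compound 2 (0.60 log units; beyond the scatter), came with a methoxy in place of hydrogen on an aromatic carbon. Going by the values given here, compound 2 therefore stands at the highest of the two numbers so far, with compound 1 as its only neighbour.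

Compound 3 `C=CC(=O)Nc1cccc(NC(=O)CSc2nc(Nc3ccc(F)cc3)c3ccccc3n2)c1` is not yet measured. Its change from compound 2 is 4-fluorophenyl in place of 3-methoxyphenyl on a nitrogen on an aromatic ring. Among the compounds with values here, no step in the data covers a fluorine on this phenyl, so the only guide is that compound 2, which carries the methoxy, reads weaker than compound 1, which carries none: the move to compound 3 removes that methoxy. The expectation is therefore a step in this assay of about a 2.9-fold lower number from compound 2 to compound 3 (0.46 log units; beyond the scatter), towards the number of compound 1. For compound 3 the estimated value in this assay is 12000 nM, with a range from 4000 nM to 40000 nM.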

Compound 3, half-maximal inhibitory concentration: 8240 nM
Compound 3: the middle estimate sits 1.5-fold (0.16 log units) above what was measured, within the range that was stated.
By their numbers in this assay, from the lowest: compounds 3 and 1 (each within the scatter of the next); then compound 2.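

The change from 3-methoxyphenyl to 4-fluorophenyl on the nitrogen gave a 4.2-fold lower number from compound 2 to compound 3 (0.63 log units; beyond the scatter) in this assay, so this position can carry a substituent without the higher number seen for compound 2. Fluoro in place of hydrogen gave a 1.1-fold lower number from compound 1 to compound 3 (0.03 log units; within the scatter), which places compound 1 and compound 3 level with each other; among the three compounds, the higher number therefore belongs to compound 2 alone, and a substituent on this phenyl does not bring it in every case. Nothing at hand bears on why the numbers fall this way.

The step to compound 3 swaps both the group and its place on the phenyl, so these compounds cannot say whether the higher number of compound 2 follows the methoxy itself or its place, which a 4-methoxyphenyl or a 3-fluorophenyl on the same nitrogen would help to settle. From the compounds shown here alone, it also remains open how this position would respond to groups of another kind, such as a dimethylamino group, a carboxylic acid or a longer alkoxy chain on the phenyl.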